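A few compounds are considered here, and "the series" means these few. Any claim that something is new, unique, unknown or untested is made for them only; others in the source may bear on it.

Three measured compounds share one core and differ only in the group on a saturated ring carbon. Compound 1 `CCCCCCCCCCCCCCCCCCNC(=O)[C@H]1CSC(C2CCCCC2)N1` carries a cyclohexyl there; in a functional assay on PC-3 cells (Homo sapiens) for antiproliferative activity, read by sulforhodamine B assay (a lower number here means a stronger inhibitor, a higher number a weaker inhibitor), compound 1 gives a value that is a limit of the assay, > 20000 nM. Compound 2 `CCCCCCCCCCCCCCCCCCNC(=O)[C@H]1CSC(Cc2ccccc2)N1` carries a benzyl instead, and in this assay compound 2 gives 16400 nM. Compound 3 `CCCCCCCCCCCCCCCCCCNC(=O)[C@H]1CSC(c2c[nH]c3ccccc23)N1` carries a 1H-indol-3-yl, and in this assay compound 3 gives 11500 nM, the lowest of the two numbers shown, though its gap to compound 2 lies within the scatter. The steps between these compounds were all small: an at least 1.2-fold lower number from compound 1 to compound 2 (0.08 log units; that floor lies within the scatter), an at least 1.7-fold lower number from compound 1 to compound 3 (0.24 log units; that floor lies within the scatter) and a 1.4-fold lower number from compound 2 to compound 3 (0.15 log units; within the scatter).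

Compound 4 `CCCCCCCCCCCCCCCCCCNC(=O)[C@H]1CSC(c2ccc(N(C)C)cc2)N1` has not yet been measured and differs from compound 3 by 4-(dimethylamino)phenyl in place of 1H-indol-3-yl on a saturated ring carbon. Among the measured compounds shown here, every measured step so far exchanged the group on this same saturated ring carbon, and none of them moved the number beyond the scatter, with one value sitting at the limit of > 20000 nM in this assay, at which 1 of the 3 values shown sits. The exchange leading to compound 4 is expected to behave in the same way, with no step beyond the scatter, a 1.0-fold higher number from compound 3 to compound 4 (0.02 log units; within the scatter). Compound 4 is estimated at 12000 nM in this assay, within a range from 5000 nM to 30000 nM.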

Compound 4, half-maximal inhibitory concentration: 6000 nM
Beside the measured number, compound 4's estimate is 2.0-fold (0.30 log units) above it; measured number inside the range.
By their numbers in this assay, from the lowest: compounds 4, 3 and 2 (each within the scatter of the next, the first and the last beyond it). At a limit, above all of these: compound 1.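

Among the compounds shown here, for the first time, an exchange on this saturated ring carbon moves the number beyond the scatter in this assay: replacing benzyl with 4-(dimethylamino)phenyl gives a 2.7-fold lower number from compound 2 to compound 4 (0.44 log units; beyond the scatter), and replacing cyclohexyl with it gives an at least 3.3-fold lower number from compound 1 to compound 4 (0.52 log units; beyond the scatter). The second of these steps starts from compound 1, whose value is a limit and not a number, so only a floor on its size can be read: the limit of > 20000 nM in this assay, at which 1 of the 4 values shown sits. Replacing 1H-indol-3-yl with 4-(dimethylamino)phenyl gives a 1.9-fold lower number from compound 3 to compound 4 (0.28 log units; within the scatter), so compound 3 and compound 4 cannot be ranked, even though a hydrogen-bond donor leaves and a hydrogen-bond acceptor enters in this exchange.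

An unsubstituted phenyl or a 4-methoxyphenyl on this carbon would help to show whether the dimethylamino group itself matters or whether an aromatic ring attached directly to this carbon is enough. All the compounds shown also carry the same octadecyl chain, so it remains open how these numbers would respond to a shorter chain in its place.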